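Fluorinated and methoxylated anilines on the shared core

This account rests on a few compounds, and the source may have more. Where it says the series, first, only, none or still open, it means among the compounds named here.

Compound 3 `COc1cccc(Nc2nc3nonc3nc2Nc2ccccc2F)c1` stands second highest of the three measured numbers in an assay on mitochondria from L6 cells (Rattus norvegicus) for activation, with a stated time of 90 min (a higher number here means that more compound is needed for the effect, a lower number that less compound is needed), giving 830 nM. Its nearest neighbour is compound 2 `Fc1ccccc1Nc1nc2nonc2nc1Nc1cccc(F)c1F`, which in this assay gives 500 nM; the gap a 1.7-fold higher number from compound 2 to compound 3 (0.22 log units; within the scatter) lies within the scatter, so no order between the two is claimed. Furthest is compound 1 `Fc1ccc(Nc2nc3nonc3nc2Nc2ccccc2F)cc1`, at 2300 nM in this assay, and the drop a 2.8-fold lower number from compound 1 to compound 3 (0.44 log units; beyond the scatter) is beyond the scatter.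

The step to compound 4 `Oc1ccc(F)c(Nc2nc3nonc3nc2Nc2ccccc2F)c1` is 2-fluoro-5-hydroxyphenyl in place of 3-methoxyphenyl on a nitrogen on an aromatic ring. Among the compounds with values here, two measured steps bear on it. The step of a 2.8-fold lower number from compound 1 to compound 3 (0.44 log units; beyond the scatter) shows that changing the aryl group on this nitrogen can move the number by a modest amount, and a 4.6-fold lower number from compound 1 to compound 2 (0.66 log units; beyond the scatter) shows that a fluorine-bearing aryl on the same nitrogen gives the lowest number seen so far. Within the data shown here, there is no measured pair that exchanges a methoxy for a hydroxyl, and no pair that combines a fluorine with a hydroxyl, so the direction of the new step is not fixed by the data.

Compound 4 is therefore expected to fall close to compound 3, with a step of a 1.3-fold lower number from compound 3 to compound 4 (0.11 log units; within the scatter) that may well stay within the scatter. The estimate for compound 4 in this assay is 650 nM, with a range from 220 nM to 2000 nM.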

Compound 4, half-maximal effective concentration: 30000 nM
The estimate for compound 4 lay 46-fold (1.66 log units) below the measured number; measured number outside the range, above it.
By their numbers in this assay, from the lowest: compounds 2 and 3 (each within the scatter of the next); then compound 1; then compound 4.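

In this assay, the group on this nitrogen can move the number much further than the earlier modest steps suggested (  a 36-fold higher number from compound 3 to compound 4 (1.56 log units; beyond the scatter)  ). The rise holds against both fluorine-bearing neighbours (  a 60-fold higher number from compound 2 to compound 4 (1.78 log units; beyond the scatter)  ;  a 13-fold higher number from compound 1 to compound 4 (1.12 log units; beyond the scatter)  ), so among these compounds a fluorine on the aryl group does not by itself go with a low number, and 2-fluoro-5-hydroxyphenyl stands alone at the top of the series. The data shown offer no measurement that accounts for this large rise.

Within the data shown here, the single change swaps the methoxy for a hydroxyl and adds a fluorine at once, and no compound here carries the hydroxyl without the fluorine or the fluorine with the methoxy kept, so the share of each in the rise stays unresolved. As far as these compounds go, it is also open how an amine or a carboxylic acid in place of the hydroxyl would read in this assay, and whether the rise would persist with a group other than the 2-fluorophenyl on the second nitrogen of the shared core.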